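The source may report more compounds than this note shows. Statements on the series, on what has been measured and on what is new or still open speak of the compounds shown alone.

Among the measured compounds shown here, the three compounds measured so far share one core and differ only in the aryl group attached to it. Compound 1 `COc1cc(C(=O)c2sc(-c3ccc(C)cc3)cc2N)cc(OC)c1OC` carries a 4-methylphenyl group there and gives 15 nM in a functional assay on CCRF-CEM cells (Homo sapiens) for antiproliferative activity (a lower number here means a stronger inhibitor, a higher number a weaker inhibitor), the lowest of the three numbers. Compound 2 `COc1cc(C(=O)c2sc(-c3ccc(Cl)c(Cl)c3)cc2N)cc(OC)c1OC` carries 3,4-dichlorophenyl and gives 290 nM. Compound 3 `COc1cc(C(=O)c2sc(-c3ccncc3)cc2N)cc(OC)c1OC` carries pyridin-4-yl and gives 110 nM. Both changes away from compound 1 weaken inhibition: a 19-fold higher number from compound 1 to compound 2 (1.29 log units; beyond the scatter) and a 7.3-fold higher number from compound 1 to compound 3 (0.87 log units; beyond the scatter). Between the two weaker compounds, a 2.6-fold lower number from compound 2 to compound 3 (0.42 log units; beyond the scatter).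

Compound 4 `COc1cccc(-c2cc(N)c(C(=O)c3cc(OC)c(OC)c(OC)c3)s2)c1` has not yet been measured. It differs from compound 1 in one place: 3-methoxyphenyl in place of 4-methylphenyl on an aromatic carbon. The two measured steps from compound 1 bear on this one, since each also exchanges the 4-methylphenyl group for another ring on the same aromatic carbon, and each gave a higher number, one large and one modest. A 3-methoxyphenyl group is neither of those rings, so the size of the loss is uncertain, but the direction in both known cases was toward weaker inhibition. Compound 4 is therefore expected to give a somewhat higher number than compound 1, a step of about a 2.7-fold higher number from compound 1 to compound 4 (0.43 log units; beyond the scatter). The estimate for compound 4 is 40 nM, with a range from 12 nM to 150 nM.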

Compound 4, half-maximal inhibitory concentration: 16 nM
Compound 4: middle estimate off by 2.5-fold (0.40 log units), on the high side; measured number inside the range.
By their numbers in this assay, from the lowest: compounds 1 and 4 (each within the scatter of the next); then compound 3; then compound 2.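

The result shows that this aromatic carbon, next to the ring sulfur, does not depend on the 4-methylphenyl group: in this assay, 3-methoxyphenyl takes its place with no change beyond the scatter (a 1.1-fold higher number from compound 1 to compound 4 (0.03 log units; within the scatter)). The same 3-methoxyphenyl ring stands well apart from the two earlier replacements (a 6.9-fold lower number from compound 3 to compound 4 (0.84 log units; beyond the scatter); an 18-fold lower number from compound 2 to compound 4 (1.26 log units; beyond the scatter)), so the earlier losses belong to pyridin-4-yl and 3,4-dichlorophenyl in particular, not to every exchange of the 4-methylphenyl group. No measurement shown here gives a reason for these differences.

The compounds shown leave open how 4-methoxyphenyl would compare with 3-methoxyphenyl, and how an unsubstituted phenyl ring would compare with both. They also leave open whether the shared standing of compound 1 and compound 4 would hold for a phenyl ring carrying a dimethylamino group, a carboxylic acid or a longer chain such as butoxy.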